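The compounds below may be only part of what the source reports. "The series", "measured", "known", "first", "only" and "open" are said of these compounds alone.

Of the compounds shown here, three built on one shared core have been tested in an assay on membranes from HeLa cells for displacement of a labelled ligand from adenosine receptor A3 (Homo sapiens), read by scintillation counting, with a stated time of 180 min, tested at 1 uM; on this read-out higher numbers stand for more inhibition at the one concentration tested (going by the name of the read-out) and lower numbers for less inhibition. Compound 1 `CCCOC(=O)C1=C(C)NC(=O)NC1c1ccco1` gives 3%, and compound 2 `CCCOC(=O)C1=C(C)NC(=O)NC1c1ccoc1` gives 11%. For the measured compounds named here, the single change between them, furan-3-yl in place of furan-2-yl on a saturated ring carbon, moves the reading by a number 8 percentage points higher from compound 1 to compound 2 (within the scatter), a shift within the usual scatter. Compound 3 `COC(=O)C1=C(C)NC(=O)NC1c1cccs1` gives 3%. On these numbers compound 3 stands level with compound 1 at the digits given, and together they are the lowest of the three readings, with compound 2 the furthest away from compound 3 while still within the scatter.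

Compound 4 `CCCOC(=O)C1=C(C)NC(=O)NC1c1cccs1` has not yet been measured. It differs from compound 3 by ethyl in place of hydrogen on a saturated chain carbon bound to an oxygen next to a carbonyl group, that is, methoxycarbonyl to propoxycarbonyl. Going by the values given here, none of the measured steps alters this ester chain on its own, so no step bears directly on the change. What can be said is that compound 1 and compound 2 both already carry the propoxycarbonyl group and give low readings, and that compound 3 with the methoxycarbonyl group sits level with compound 1. Nothing seen so far points to a shift beyond the scatter from lengthening this chain. Compound 4 is therefore expected to give about 5%, with a range from -5% to 15%. The step from compound 3 is estimated as a number 2 percentage points higher from compound 3 to compound 4 (within the scatter), which means no change beyond the scatter is expected.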

Compound 4, a percentage reported as inhibition, at one concentration (the size of the read-out at that concentration, not a potency): 32%
Beside the measured number, compound 4's estimate is 27 percentage points below it; the whole stated range lies below it.
By their numbers in this assay, from the lowest: compounds 1, 3 and 2 (each within the scatter of the next); then compound 4.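

In this assay, for the compounds shown here, the ester chain proves able to move the reading: with thiophen-2-yl on the saturated ring carbon, going from methoxycarbonyl to propoxycarbonyl gives a number 29 percentage points higher from compound 3 to compound 4 (beyond the scatter) and is the first change of this chain seen on its own. With propoxycarbonyl held fixed, the group on the ring carbon also counts: thiophen-2-yl in place of furan-3-yl gives a number 21 percentage points higher from compound 2 to compound 4 (beyond the scatter) and thiophen-2-yl in place of furan-2-yl gives a number 29 percentage points higher from compound 1 to compound 4 (beyond the scatter) while the earlier swap between the two furans stayed within the scatter. Nothing at hand explains why either change raises the reading.

As far as these compounds go, whether lengthening the chain would raise the reading in the same way with a furan on the ring carbon remains open, as does what an intermediate ethoxycarbonyl or a longer butoxycarbonyl group would give. Also open, from the compounds shown here alone, is how a phenyl ring on the ring carbon would compare with thiophen-2-yl, and these single-concentration readings do not establish the potency of any of the compounds.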